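Replacing a Chain End at the Cytotoxicity Limit

This account rests on a few compounds, and the source may have more. Where it says the series, first, only, none or still open, it means among the compounds named here.

Measured in an ADME assay on BJ cells (Homo sapiens) for cytotoxicity, with a stated time of 72 h; on this read-out higher numbers stand for an effect only at larger amounts of compound and lower numbers for an effect already at smaller amounts:
- compound 1 `C=C[C@@](C)(/C=C/c1ccc(O)cc1)CCC=O`: > 36600 nM, a limit
- compound 2 `C=C[C@@](C)(/C=C/c1ccc(O)cc1)CCCO`: > 36600 nM, a limit

Compound 2 has only a limit, > 36600 nM, and no number. The move to compound 3 `C=C[C@@](C)(/C=C/c1ccc(O)cc1)CC/C=C/C(=O)OCC` is 2-(ethoxycarbonyl)ethenyl in place of hydroxymethyl on a saturated chain carbon, three bonds along the chain from two double-bonded chain carbons. For the measured compounds named here, the one measured step, a step that the two limits leave unreadable from compound 1 to compound 2, has no readable size, and (the limit of > 36600 nM in this assay, at which 2 of the 2 values shown sit). No measured size therefore carries over, so the expectation is tentative: a modest shift towards lower numbers in this assay, with another limit quite possible. The expected step is an at least 1.2-fold lower number from compound 2 to compound 3 (0.08 log units; that floor lies within the scatter). Compound 3 is estimated at 30000 nM, within an expected range of 12000 nM to 50000 nM.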

Compound 3, half-maximal effective concentration: > 36600 nM
Compound 3: only a limit was reported; the forecaster's own chance of this, stated with the estimate: 55%; at least 1.2-fold (0.08 log units) between middle value and limit.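

In this assay compound 3 gives > 36600 nM as a limit, and no step among compound 1, compound 2 and compound 3 can be read: the limit of > 36600 nM in this assay, at which 3 of the 3 values shown sit.

The compounds shown leave open how far the three differ in this read-out, since none has a number.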